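A few compounds are considered here, and "the series" means these few. Any claim that something is new, unique, unknown or untested is made for them only; others in the source may bear on it.

Measured so far in a functional assay on PC-3 cells (Homo sapiens) for antiproliferative activity, read by MTT assay, with a stated time of 72 h; on this read-out higher numbers stand for weaker inhibition and lower numbers for stronger inhibition:
- compound 1 `O=C(N/N=C/c1ccc([N+](=O)[O-])cc1)Nc1ccc(Oc2ccnc3[nH]ccc23)c(F)c1`: 150 nM
- compound 2 `COc1ccc(/C=N/NC(=O)Nc2ccc(Oc3ccnc4[nH]ccc34)c(F)c2)c(OC)c1OC`: 8970 nM
- compound 3 `CCN(CC)CCn1cccc1/C=N/NC(=O)Nc1ccc(Oc2ccnc3[nH]ccc23)cc1`: 1370 nM

Compound 3 stands in the middle of these three numbers. Compound 2 lies higher and compound 1 lies lower, and both gaps are beyond the scatter. For the measured compounds named here, no two measured compounds differ in one place only, so the series offers no direct measure of a single change.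

The next compound is compound 4 `O=C(N/N=C/c1cccn1CCCN1CCCC1)Nc1ccc(Oc2ccnc3[nH]ccc23)cc1`. Its difference from compound 3 is (pyrrolidin-1-yl)methyl in place of diethylamino on a saturated chain carbon, two bonds along the chain from an aromatic nitrogen. In words, (pyrrolidin-1-yl)methyl stands in place of diethylamino on a saturated chain carbon, two bonds along the chain from an aromatic nitrogen. Cut one bond further out, the same difference reads 2-(diethylamino)ethyl to 3-(pyrrolidin-1-yl)propyl. Going by the values given here, the shared core stays untouched, and no measured pair shows what a change of this chain does. The expectation in this assay is therefore no step beyond the scatter, with compound 3 at 1370 nM as the anchor. The estimated 1.1-fold lower number from compound 3 to compound 4 (0.06 log units; within the scatter) is expected to stay within the scatter. For compound 4 the expected value is 1200 nM, with an estimated range of 400 nM to 3500 nM.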

Compound 4, half-maximal inhibitory concentration: 4290 nM
Compound 4: the middle estimate sits 3.6-fold (0.55 log units) below what was measured; measured number above the stated range.
By their numbers in this assay, from the lowest: compound 1; then compound 3; then compound 4; then compound 2.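

In this assay, for the compounds shown here, the side chain proves sensitive even with the shared core untouched: (pyrrolidin-1-yl)methyl in place of diethylamino on a saturated chain carbon, two bonds along the chain from an aromatic nitrogen, gives a 3.1-fold higher number from compound 3 to compound 4 (0.50 log units; beyond the scatter) as the first single-place step. This one step carries two changes at once, since 2-(diethylamino)ethyl to 3-(pyrrolidin-1-yl)propyl both lengthens the chain and closes the amine into a five-membered non-aromatic ring, and the step cannot be divided between them. Nothing at hand gives a reason for the step.

Still open, going by these compounds, is which of the two changes carries the step, a question that 2-(pyrrolidin-1-yl)ethyl or 3-(diethylamino)propyl on the same chain would separate. Also open, on these data alone, is whether other chain ends, such as a morpholine or a piperidine, follow compound 3 or compound 4, and whether the same chain change would give a similar step on the fluorine-bearing core of compound 1.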